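Thiophene in place of pyridine on a shared core

A few compounds are considered here, and "the series" means these few. Any claim that something is new, unique, unknown or untested is made for them only; others in the source may bear on it.

Measured so far in a functional assay for activation of Alpha-1D adrenergic receptor (Homo sapiens), read by calcium flux; a lower number here means that less compound is needed, a higher number that more compound is needed for the effect:
compound 1 `c1ccc(-c2ccncc2)c(OCC2=NCCN2)c1`: < 100000 nM
compound 2 `c1ccc(-c2ccncn2)c(OCC2=NCCN2)c1`: < 100000 nM
compound 3 `c1ccc(-c2ccoc2)c(OCC2=NCCN2)c1`: 5.01 nM

Three compounds share one core and differ only in the aromatic ring attached to it. In this assay compound 1 gives < 100000 nM, which is a limit of the assay and not a number. Compound 2 likewise stands at a limit, with < 100000 nM. Compound 3, carrying furan-3-yl, gives 5.01 nM. Two of the three values thus sit at the limit of < 100000 nM in this assay, at which 2 of the 3 values shown sit, so the steps a step that the two limits leave unreadable from compound 1 to compound 2, a step that the limit leaves unreadable from compound 1 to compound 3 and a step that the limit leaves unreadable from compound 2 to compound 3 cannot be read in size.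

Compound 4 `c1ccc(-c2ccsc2)c(OCC2=NCCN2)c1` is not yet measured. It differs from compound 1 by thiophen-3-yl in place of pyridin-4-yl on an aromatic carbon. Within the data shown here, the only step of comparable kind, from pyridin-4-yl to a five-membered ring, is a step that the limit leaves unreadable from compound 1 to compound 3, whose size is hidden by the limit of compound 1. Since compound 3 with furan-3-yl gives 5.01 nM, compound 4 with the related thiophen-3-yl is expected to reach a similar value, and the step that the limit leaves unreadable from compound 1 to compound 4 is expected to be large toward less compound needed. The estimate for compound 4 is 10 nM, ranging from 2 nM to 60 nM.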

Compound 4, half-maximal effective concentration: 12.6 nM
Compound 4: middle estimate off by 1.3-fold (0.10 log units), on the low side; the measured number falls inside the stated range.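

Changing furan-3-yl to thiophen-3-yl at this position on the aromatic ring gives a 2.5-fold higher number from compound 3 to compound 4 (0.40 log units; beyond the scatter) in this assay. A readable value here is therefore not unique to furan-3-yl: a second five-membered aromatic ring with one hetero atom also gives one, and exchanging oxygen for sulfur in that ring changes the number only modestly. The steps to compound 4 from compound 1 and from compound 2 still cannot be read, since both of those compounds stand at a limit, not a number: the limit of < 100000 nM in this assay, at which 2 of the 4 values shown sit.

The compounds shown leave open how a plain phenyl ring would behave here, and whether an amine or a carboxylic acid on the five-membered ring would keep a readable value. They also leave open whether ring size or the kind of hetero atom counts for more.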